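Phenyl in place of heptyl: compound 3 to compound 4

The compounds below may be only part of what the source reports. "The series", "measured", "known", "first", "only" and "open" are said of these compounds alone.

The set shares a sulfonamide core built on a six-membered non-aromatic ring that carries a chloro group. Compound 1 `CCCCCCC[C@H]1C[C@H](Cl)CCN1S(=O)(=O)c1ccc(C)cc1` reaches only a limit in a functional assay on A2780 cells (Homo sapiens) for antiproliferative activity, read by sulforhodamine B assay, with a stated time of 48 h; a lower number here means a stronger inhibitor of growth, a higher number a weaker inhibitor of growth; there compound 1 gives > 100000 nM. Compound 2 `Cc1ccc(S(=O)(=O)N2CC=C(Cl)CC2)cc1` also stops at a limit, and in this assay compound 2 gives > 100000 nM. Going by the values given here, compound 3 `CCCCCCCC1C=C(Cl)CCN1S(=O)(=O)c1ccc(C)cc1` is the single member with a number: in this assay compound 3 gives 92000 nM. That number stands alone among the shown values, the other two being limits (the limit of > 100000 nM in this assay, at which 2 of the 3 values shown sit). Among the compounds with values here, the one measured step, an at least 1.0-fold lower number from compound 2 to compound 3 (0.03 log units; that floor lies within the scatter), adds heptyl on a saturated ring carbon and stays within the scatter.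

Compound 4 `Cc1ccc(S(=O)(=O)N2CCC(Cl)=CC2c2ccccc2)cc1` differs from compound 3 by phenyl in place of heptyl on a saturated ring carbon. Within the data shown here, no measured step exchanges one carbon group for another at this carbon; the only step available, which adds a group there, gave no movement beyond the scatter. For compound 4 the expected step of a 1.1-fold higher number from compound 3 to compound 4 (0.04 log units; within the scatter) is therefore estimated to stay within the scatter. Compound 4 is expected near 100000 nM, within 30000 nM to 300000 nM, with a real chance that only a limit is reported.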

Compound 4, concentration for 50% growth inhibition: 17000 nM
Compound 4: middle estimate off by 5.9-fold (0.77 log units), on the high side, and the stated range ends above it.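

At the saturated ring carbon next to the ring nitrogen, the kind of carbon group matters in this assay: phenyl in place of heptyl gives a 5.4-fold lower number from compound 3 to compound 4 (0.73 log units; beyond the scatter). Phenyl in place of hydrogen at the same carbon gives an at least 5.8-fold lower number from compound 2 to compound 4 (0.76 log units; beyond the scatter), so a group here can move the number beyond the scatter, which heptyl did not show. This step is only a floor because compound 2 stands at a limit: the limit of > 100000 nM in this assay, at which 2 of the 4 values shown sit.

From the compounds shown here alone, whether the change comes from the aromatic ring or from the loss of the open chain remains open, and a cyclohexyl or benzyl group at this carbon would separate the two. Also open, going by these compounds, is whether a phenyl ring carrying an amine or a carboxylic acid would shift the number further.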